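Compound 3 to compound 4: a change of aryl group

The source may report more compounds than this note shows. Statements on the series, on what has been measured and on what is new or still open speak of the compounds shown alone.

In a functional assay on MCF7 cells (Homo sapiens) for inhibition, read by sulforhodamine B assay (a lower number here means a stronger inhibitor of growth, a higher number a weaker inhibitor of growth), compound 3 (`COc1ccc(-c2ccc(-c3ccc(-c4nc5ccccc5[nH]4)cc3)cc2)cc1`) gives 33300 nM and stands level with compound 2 (`FC(F)(F)c1ccc(-c2ccc(-c3ccc(-c4nc5ccccc5[nH]4)cc3)cc2)cc1`) at 41400 nM, within the scatter, while compound 1 (`Cc1ccc2[nH]c(-c3ccc(-c4ccc(-c5cccc(Cl)c5)cc4)cc3)nc2c1`) at 1210 nM is clearly lower than both.

Compound 4 (`Clc1cccc(-c2ccc(-c3ccc(-c4nc5ccccc5[nH]4)cc3)cc2)c1`) carries 3-chlorophenyl in place of 4-methoxyphenyl on an aromatic carbon, para to a large group (3-chlorophenyl in place of 4-methoxyphenyl on an aromatic carbon).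

Within the data shown here, the one measured step, a 1.2-fold lower number from compound 2 to compound 3 (0.09 log units; within the scatter), exchanges trifluoromethyl for methoxy and stays within the scatter, so it offers no guide to the size of this change. Compound 1 also carries 3-chlorophenyl and gives 1210 nM, but the core of compound 1 differs from that of compound 4, and no measurement separates the two differences. Only part of the gap between compound 3 and compound 1 is therefore expected to appear here. The expected move, toward a lower number, is an 8.3-fold lower number from compound 3 to compound 4 (0.92 log units; beyond the scatter) in this assay, with wide uncertainty. Compound 4 is estimated at 4000 nM (expected range 1000 nM to 20000 nM).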

Compound 4, concentration for 50% growth inhibition: 36300 nM
For compound 4 the middle estimate is 9.1-fold (0.96 log units) below the measured one; the measured number lies above the stated range.
By their numbers in this assay, from the lowest: compound 1; then compounds 3, 4 and 2 (each within the scatter of the next).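

In this assay, the exchange of aryl groups at this position leaves the number unmoved: a 1.1-fold higher number from compound 3 to compound 4 (0.04 log units; within the scatter) and a 1.1-fold lower number from compound 2 to compound 4 (0.06 log units; within the scatter), so 3-chlorophenyl, 4-methoxyphenyl and 4-(trifluoromethyl)phenyl stand level. Among these compounds, the large step lies instead in the single change on the core, hydrogen in place of methyl on an aromatic carbon, a 30-fold higher number from compound 1 to compound 4 (1.48 log units; beyond the scatter), which places the low number of compound 1 with that methyl and not with 3-chlorophenyl. No available measurement accounts for either result.

From the compounds shown here alone, whether the methyl step carries over to compounds bearing 4-methoxyphenyl or 4-(trifluoromethyl)phenyl remains open. Also open, going by these compounds, are whether ethyl, methoxy or chlorine on that core carbon would match methyl, and whether an amine or a carboxylic acid on the aryl group would move the number at all.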